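A few compounds are considered here, and "the series" means these few. Any claim that something is new, unique, unknown or untested is made for them only; others in the source may bear on it.

Measured compounds:
compound 1 `CCCCCc1cc2c(=O)n(CC3CC3)cnc2s1`: > 100 ug/mL
compound 2 `CCCCCCc1cc2c(=O)n(CC3CC3)cnc2s1`: > 100 ug/mL
compound 3 `CCCCCCc1cc2c(=O)n(CCN=[N+]=[N-])cnc2s1`: > 100 ug/mL

Each of these three values is a limit of an ADME assay on THP-1 cells (Homo sapiens) for cytotoxicity, read by MTT assay, with a stated time of 11 days (a lower number here means a stronger inhibitor of growth, a higher number a weaker inhibitor of growth), not a number. The step that the two limits leave unreadable from compound 1 to compound 2 is methyl in place of hydrogen on a saturated chain carbon, five bonds along the chain from an aromatic carbon. The step that the two limits leave unreadable from compound 2 to compound 3 swaps the group on the aromatic nitrogen. All three values sit at the limit of > 100 ug/mL in this assay, at which 3 of the 3 values shown sit.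

Compound 4 `CCCCCCCc1cc2c(=O)n(CCN=[N+]=[N-])cnc2s1` is not yet measured in this assay. Against compound 3 it carries methyl in place of hydrogen on a saturated chain carbon, six bonds along the chain from an aromatic carbon, the same kind of change as from compound 1 to compound 2, though set six bonds rather than five bonds along the chain from the aromatic carbon. The difference between the core of compound 1 and the core of compound 3 is not broken down here.

The expected step that the limit leaves unreadable from compound 3 to compound 4 is small, resting on a step that the two limits leave unreadable from compound 1 to compound 2, which stayed within the limit. Compound 4 is therefore estimated at 130 ug/mL, most likely again reported only as a limit.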

Compound 4, concentration for 50% growth inhibition: > 100 ug/mL
Compound 4 was reported as a limit (the forecaster's own chance of this, stated with the estimate: 80%); the middle value does not contradict the limit.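

Compound 3 and compound 4 are both reported as limits, not numbers, so no step can be read between them. The size of any chain or nitrogen-group change in this assay stays open, since every value shown sits at one limit: the limit of > 100 ug/mL in this assay, at which 4 of the 4 values shown sit.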